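The source may hold more compounds than are shown below. What is called first, only, known or untested is meant among the compounds shown, and "the series" means these compounds.

Three compounds share one core. Compound 1 `CC1(C)O[C@@H](CO)[C@H](Cn2cc(Cn3c4c(c5ccccc53)C(=O)c3c[n+]([O-])c5ccccc5c3C4=O)nn2)O1` gives in a functional assay on A-375 cells (Homo sapiens) for cytotoxicity, read by MTT assay, with a stated time of 72 h (on this read-out higher numbers stand for weaker inhibition and lower numbers for stronger inhibition), a value of 190 nM, the lowest of the three numbers. Compound 2 `O=C1c2c[n+]([O-])c3ccccc3c2C(=O)c2[nH]c3ccccc3c21` carries only hydrogen on an aromatic nitrogen and gives 660 nM; compound 3 `CN1CCN(CCCn2c3c(c4ccccc42)C(=O)c2c[n+]([O-])c4ccccc4c2C3=O)CC1` gives 470 nM. Among the compounds with values here, the only measured step, a 1.4-fold lower number from compound 2 to compound 3 (0.15 log units; within the scatter), alters that aromatic nitrogen and leaves the five-membered non-aromatic ring with 2 oxygen untouched. Compound 4 `CC1(C)OC[C@H](Cn2cc(Cn3c4c(c5ccccc53)C(=O)c3c[n+]([O-])c5ccccc5c3C4=O)nn2)O1` differs from compound 1 by hydrogen in place of hydroxymethyl on a saturated ring carbon. Within the data shown here, no measured step concerns this ring position, so the data give no direction for the change, and a step within the scatter is expected: a 1.2-fold higher number from compound 1 to compound 4 (0.06 log units; within the scatter). Compound 4 is accordingly estimated at 220 nM, with a range from 100 nM to 500 nM.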

Compound 4, half-maximal inhibitory concentration: 180 nM
Beside the measured number, compound 4's estimate is 1.2-fold (0.09 log units) above it, within the range that was stated.
By their numbers in this assay, from the lowest: compounds 4 and 1 (each within the scatter of the next); then compounds 3 and 2 (each within the scatter of the next).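

Replacing hydroxymethyl with hydrogen on this saturated ring carbon gives a 1.1-fold lower number from compound 1 to compound 4 (0.02 log units; within the scatter) in this assay and so stays within the scatter. Within the data shown here, this is the first measured change at this ring position, and it shows that compound 1 does not need its hydroxymethyl to keep its number in this read-out. No available evidence explains this result. Still open, going by these compounds, is whether an amine, a carboxylic acid or a longer chain such as hydroxyethyl on this ring carbon would leave the number equally unchanged.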